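The compounds below may be only part of what the source reports. "The series", "measured", "known", "first", "only" and "open" are said of these compounds alone.

Measured compounds, growth inhibition in a functional assay on DU-145 cells (Homo sapiens), with a stated time of 96 h; on this read-out higher numbers stand for weaker inhibition of growth and lower numbers for stronger inhibition of growth:

compound 1 `CCOc1cccc2cc(S(=O)(=O)Nc3ccc(OC)cc3)c(=O)oc12` gives 57000 nM
compound 2 `CCOc1cccc2cc(S(=O)(=O)Nc3ccc(F)c(N)c3)c(=O)oc12` gives 48000 nM
compound 3 `CCOc1cccc2cc(S(=O)(=O)Nc3ccc(Br)cc3)c(=O)oc12` gives 52000 nM

All three numbers lie within the scatter of one another. Compound 3 stands second highest of the three: against compound 1 the step is a 1.1-fold lower number from compound 1 to compound 3 (0.04 log units; within the scatter), and against compound 2 it is a 1.1-fold higher number from compound 2 to compound 3 (0.03 log units; within the scatter). No ordering among the three can be read from this.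

Compound 4 `O=c1oc2c(Cl)cccc2cc1S(=O)(=O)Nc1ccc(Br)cc1` differs from compound 3 only at the core: chloro in place of ethoxy on an aromatic carbon. The sulfonamide substituent, 4-bromophenyl, is kept.

Within the data shown here, none of the measured steps touches the position changed here. The three steps, a 1.2-fold lower number from compound 1 to compound 2 (0.07 log units; within the scatter), a 1.1-fold lower number from compound 1 to compound 3 (0.04 log units; within the scatter) and a 1.1-fold higher number from compound 2 to compound 3 (0.03 log units; within the scatter), all exchange the group on the sulfonamide nitrogen, and all stay within the scatter. So the series says only that this assay has so far been insensitive to the variation tried; about swapping ethoxy for chloro on the core it says nothing directly. Without a relevant comparison, the expectation in this assay is no step beyond the scatter, with a range widened to reflect the untested position: the step from compound 3 to compound 4 is estimated as no change at the digits printed from compound 3 to compound 4 (within the scatter). Compound 4 is therefore expected to give about 52000 nM, in the range 20000 nM to 130000 nM.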

Compound 4, concentration for 50% growth inhibition: 14000 nM
Compound 4: the middle estimate sits 3.7-fold (0.57 log units) above what was measured; the whole stated range lies above it.
By their numbers in this assay, from the lowest: compound 4; then compounds 2, 3 and 1 (each within the scatter of the next).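

In this assay, among these compounds, the exchange of ethoxy for chloro on the core gives a 3.7-fold lower number from compound 3 to compound 4 (0.57 log units; beyond the scatter) and is the first single change to move the number beyond the scatter, whereas every exchange on the sulfonamide nitrogen stayed within it. The position on the six-membered aromatic ring of carbon only, ortho to a fused ring, therefore responds in this assay where the group on the sulfonamide nitrogen so far has not, although the step is modest and rests on one pair with 4-bromophenyl kept. No measurement shown bears on why chloro and ethoxy differ here.

From the compounds shown here alone, whether the lower number belongs to chloro itself or simply to the removal of ethoxy stays open, and a hydrogen, a fluoro, a methoxy or an amine at the same position would help separate the two. Also open, going by these compounds, is whether the step carries over to other sulfonamide substituents, since 3-amino-4-fluorophenyl and 4-methoxyphenyl appear here only with ethoxy on the core.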